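This account rests on a few compounds, and the source may have more. Where it says the series, first, only, none or still open, it means among the compounds named here.

Working notes on the series. Compound 1 `CN(C)C(=O)CN1CCC(c2cc3c(-c4ccc(=O)n(C)c4)ccnc3[nH]2)CC1` sits at the floor of an ADME assay on cells (Hepatocyte, Rattus norvegicus) for metabolic stability; a higher number here means faster removal of the compound, a lower number slower removal: the reading for compound 1 is < 1 uL/min, which is a limit of the assay and not a number (the limit of < 1 uL/min in this assay, at which 1 of the 3 values shown sits). Compound 2 `CN(C)C(=O)CN1CCC(c2cc3c(-c4ccc(=O)n(C5CCOCC5)c4)ccnc3[nH]2)CC1` carries oxan-4-yl in place of methyl on the aromatic nitrogen, and in this assay compound 2 gives 2.3 uL/min. Compound 3 `CC(C)Cn1cc(-c2ccnc3[nH]c(C4CCN(CC(=O)N(C)C)CC4)cc23)ccc1=O` carries isobutyl there, and in this assay compound 3 gives 6.6 uL/min. The measured steps all run upward: an at least 2.3-fold higher number from compound 1 to compound 2 (0.36 log units; beyond the scatter), an at least 6.6-fold higher number from compound 1 to compound 3 (0.81 log units; beyond the scatter) and a 2.9-fold higher number from compound 2 to compound 3 (0.46 log units; beyond the scatter). Across these three compounds, a larger group on the aromatic nitrogen has gone with a higher number each time; no compound among the three goes against this.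

Compound 4 `CC(C)n1cc(-c2ccnc3[nH]c(C4CCN(CC(=O)N(C)C)CC4)cc23)cnc1=O` is not yet measured. It differs from compound 1 as follows: a group of 10 heavy atoms (7 carbon, 2 nitrogen, 1 oxygen; one six-membered aromatic ring with 2 hetero atoms) in place of a group of 8 heavy atoms (6 carbon, 1 nitrogen, 1 oxygen; one six-membered aromatic ring with 1 hetero atom), on an aromatic carbon. The new ring carries isopropyl on its nitrogen and an additional ring nitrogen. The steps from compound 1 to compound 2 and from compound 1 to compound 3 both bear on this change, since both enlarge the group on that nitrogen, and both were at least modest in the upward direction. For compound 4 an upward step of an at least 3.0-fold higher number from compound 1 to compound 4 (0.47 log units; beyond the scatter) is therefore expected, with the added ring nitrogen leaving the size uncertain. The estimate for compound 4 in this assay is 3 uL/min, within 1 uL/min to 8 uL/min.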

Compound 4, intrinsic clearance in a liver preparation (reported as CLH), per the amount of preparation that the assay uses: 100 uL/min
The estimate for compound 4 lay 33-fold (1.52 log units) below the measured number; the measured number lies above the stated range.
By their numbers in this assay, from the lowest: compound 2; then compound 3; then compound 4. At a limit, below all of these: compound 1.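

In this assay, within the data shown here, the exchange on this aromatic carbon, opposite the ring nitrogen, gives an at least 100-fold higher number from compound 1 to compound 4 (2.00 log units; beyond the scatter), the only step graded large. Unlike the earlier steps, which changed only the group on the aromatic nitrogen, this one also brings an additional ring nitrogen, so the trend with group size among compound 1, compound 2 and compound 3 no longer describes the whole change at this position. The reading for compound 1 is a limit of the assay and not a number, so the step has a lower bound only: the limit of < 1 uL/min in this assay, at which 1 of the 4 values shown sits.

As far as these compounds go, it remains open how this step divides between isopropyl on the nitrogen and the additional ring nitrogen, a question that would need the ring of compound 1 with isopropyl and the ring of compound 4 with methyl, each read in this assay. Also open, from the compounds shown here alone, is how the ring of compound 4 would read with a group of another kind on its nitrogen, such as a carboxylic acid on a short chain or a primary amine.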